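This account rests on a few compounds, and the source may have more. Where it says the series, first, only, none or still open, it means among the compounds named here.

Measured so far in an assay for inhibition of Alpha amylase (Homo sapiens), with a stated time of 10 min; a lower number here means a stronger inhibitor, a higher number a weaker inhibitor:
compound 1 `COc1cc(Br)c(-c2nc3ccccc3[nH]2)cc1OC`, 1510 nM
compound 2 `Oc1c(Br)cc(Cl)cc1-c1nc2ccccc2[nH]1`, 2850 nM
compound 3 `Cc1cc2nc(-c3cc(O)ccc3O)[nH]c2cc1C`, 2990 nM

Compound 2 gives the second highest of the three numbers; compound 3 is nearest and compound 1 furthest, but both differences lie within the scatter, so no order among the three can be read from these numbers. Within the data shown here, no two measured compounds differ in only one place, so no single step has been measured yet.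

Compound 4 `Oc1c(Br)cc(Cl)cc1-c1nc2cc(Cl)ccc2[nH]1` is the next to be measured. It differs from compound 2 by chloro in place of hydrogen on an aromatic carbon. Among the measured compounds shown here, with no measured step of this kind available, a change of no more than the usual scatter is expected in this assay, in either direction. The estimate for compound 4 is 2500 nM, expected to fall between 900 nM and 7000 nM, which amounts to an expected step of a 1.1-fold lower number from compound 2 to compound 4 (0.06 log units; within the scatter).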

Compound 4, half-maximal inhibitory concentration: 2860 nM
Compound 4: the middle estimate sits 1.1-fold (0.06 log units) below what was measured; low and high end bracket the measured number.
By their numbers in this assay, from the lowest: compounds 1, 2, 4 and 3 (each within the scatter of the next).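

In this assay, chloro in place of hydrogen on an aromatic carbon of the fused system of two rings gives a 1.0-fold higher number from compound 2 to compound 4 (0.00 log units; within the scatter), the first single step measured in this series. On the core of compound 2, this position therefore accepts a chlorine with no change beyond the scatter. No evidence bearing on this result is available.

From the compounds shown here alone, whether an amine, a carboxylic acid or a longer chain at this position would also leave the number within the scatter remains open. So does whether chloro gives a similar step on the core of compound 1.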